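Swapping cyano for trifluoromethyl on the benzyl ether

The compounds below may be only part of what the source reports. "The series", "measured", "known", "first", "only" and "open" are said of these compounds alone.

Three compounds share one core and differ only in the group on the benzyl ring. Compound 1 `COc1cc(OC)c(-c2coc3cc(OCc4ccccc4F)ccc3c2=O)cc1OC` gives 1280 nM in a functional assay on HepG2 cells (Homo sapiens) for antiproliferative activity, read by MTT assay, with a stated time of 24 h; on this read-out higher numbers stand for weaker inhibition and lower numbers for stronger inhibition. Compound 2 `COc1cc(OC)c(-c2coc3cc(OCc4ccc(F)cc4)ccc3c2=O)cc1OC` gives 1000 nM in this assay, and compound 3 `COc1cc(OC)c(-c2coc3cc(OCc4ccc(C#N)cc4)ccc3c2=O)cc1OC` gives 4230 nM. Compound 3 thus stands highest of the three: a 3.3-fold higher number from compound 1 to compound 3 (0.52 log units; beyond the scatter) and a 4.2-fold higher number from compound 2 to compound 3 (0.63 log units; beyond the scatter), both beyond the scatter, so compound 3 is the weakest inhibitor here.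

Compound 4 `COc1cc(OC)c(-c2coc3cc(OCc4ccc(C(F)(F)F)cc4)ccc3c2=O)cc1OC` differs from compound 3 in one place: trifluoromethyl in place of cyano on an aromatic carbon. Going by the values given here, no measured step involves a trifluoromethyl group, so the direct size of this change is unknown. The step that bears most is the one at the same aromatic carbon, a 4.2-fold higher number from compound 2 to compound 3 (0.63 log units; beyond the scatter), which shows that a change of the group in that position can move the number modestly. Since that step raised the number and compound 4 now leaves cyano behind, a modest step back downward is expected, a 2.1-fold lower number from compound 3 to compound 4 (0.33 log units; beyond the scatter), and compound 4 is estimated at 2000 nM, within 800 nM to 5000 nM.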

Compound 4, half-maximal inhibitory concentration: 890 nM
For compound 4 the middle estimate is 2.2-fold (0.35 log units) above the measured one; low and high end bracket the measured number.
By their numbers in this assay, from the lowest: compounds 4, 2 and 1 (each within the scatter of the next); then compound 3.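

Trifluoromethyl in place of cyano gives a 4.8-fold lower number from compound 3 to compound 4 (0.68 log units; beyond the scatter) in this assay, so the higher number seen with cyano is not shared by every replacement of fluoro at this aromatic carbon. Trifluoromethyl and fluoro cannot be told apart here, with a 1.1-fold lower number from compound 2 to compound 4 (0.05 log units; within the scatter), and the same holds for the change from 2-fluorophenyl to 4-(trifluoromethyl)phenyl, with a 1.4-fold lower number from compound 1 to compound 4 (0.16 log units; within the scatter), which leaves compound 3 as the only one of the four set apart from the others. Nothing measured on these compounds explains why cyano stands apart.

From the compounds shown here alone, whether an amine, a carboxylic acid or a methoxy group on this carbon would track with cyano or with fluoro and trifluoromethyl stays open. Also open, going by these compounds, is how trifluoromethyl would behave on the ring carbon that carries fluorine in compound 1.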